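The compounds below may be only part of what the source reports. "The series", "measured", "known", "first", "only" and "open" are said of these compounds alone.

In a functional assay on HepG2 cells (Homo sapiens) for antiproliferative activity, with a stated time of 72 h (a higher number here means that more compound is needed for the effect, a lower number that less compound is needed), compound 1 `COc1ccc(-c2cc(=O)c3c(OC)cc(OC)cc3n2S(=O)(=O)c2ccc(C=O)cc2)cc1` reaches only a limit, > 34400 nM. Compound 2 `COC(=O)c1cc(=O)c2cc(NC(=O)Nc3ccc(Cl)c(C(F)(F)F)c3)ccc2[nH]1` likewise gives only a limit, > 6350 nM. Compound 3 `COC(=O)c1cc(=O)c2cc(NC(=O)Nc3ccc(Cl)c(Cl)c3)ccc2[nH]1` also stops at a limit, > 6350 nM. Going by the values given here, the single measured step, a step that the two limits leave unreadable from compound 2 to compound 3, cannot be sized, since both of its ends rest on the limit of > 6350 nM in this assay, at which 2 of the 3 values shown sit, while the remaining value sits at the limit of > 34400 nM in this assay, at which 1 of the 3 values shown sits. Compound 3 thus stands level with everything shown: all three values are limits, none is a number. Compound 4 `COC(=O)c1cc(=O)c2cc(NC(=O)Nc3ccc(F)c(Cl)c3)ccc2[nH]1` differs from compound 3 by fluoro in place of chloro on an aromatic carbon. Among the compounds with values here, no measured step bears on this change, so nothing beyond the scatter is expected in either direction, and the expected step is a step that the limit leaves unreadable from compound 3 to compound 4. Compound 4 is estimated at 10000 nM, within 3000 nM to 40000 nM, most likely again a limit in this assay.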

Compound 4, half-maximal effective concentration: > 6350 nM
Compound 4: no number, only a limit (the forecaster's own chance of this, stated with the estimate: 85%); the middle value does not contradict the limit.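

Compound 3 and compound 4 both stop at a limit in this assay, so no new step can be read between them. The compounds shown leave open whether fluoro in place of chloro changes the antiproliferative effect at all.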